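Trifluoromethyl gives way to methoxy on compound 2

The source may hold more compounds than are shown below. What is called first, only, known or untested is meant among the compounds shown, and "the series" means these compounds.

In a functional assay on HUVEC cells (Homo sapiens) for inhibition, with a stated time of 4 days (a lower number here means a stronger inhibitor, a higher number a weaker inhibitor), compound 1 `COc1ccc(C(N)=O)cc1COc1ccc(Cl)c(C)c1` gives 640 nM and compound 2 `COc1ccc(C(N)=O)cc1/C=C/c1ccc(C(F)(F)F)cc1` gives 880 nM, so compound 2 stands within the usual scatter of compound 1. Compound 3 `COc1ccc(/C=C/c2cc(C(N)=O)ccc2OC)cc1` carries methoxy in place of trifluoromethyl on an aromatic carbon, para to a large group (methoxy in place of trifluoromethyl on an aromatic carbon). Among the compounds with values here, no measured pair shows what this exchange does in this assay, so no step beyond the scatter is expected, in either direction. The estimated step is a 1.3-fold lower number from compound 2 to compound 3 (0.10 log units; within the scatter). Compound 3 is expected at 700 nM, with an estimated range from 220 nM to 2200 nM.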

Compound 3, half-maximal inhibitory concentration: 8800 nM
Compound 3: middle estimate off by 13-fold (1.10 log units), on the low side; the measured number lies above the stated range.
By their numbers in this assay, from the lowest: compounds 1 and 2 (each within the scatter of the next); then compound 3.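

Within the data shown here, this position is sensitive to the group it carries, which the earlier compounds, with no measured pair between them, could not show. On an aromatic carbon, para to a large group, methoxy in place of trifluoromethyl gives in this assay a 10-fold higher number from compound 2 to compound 3 (1.00 log units; beyond the scatter) and thus a weaker inhibitor, a step beyond the scatter. Nothing available here bears on what lies behind this loss.

From the compounds shown here alone, whether a chlorine, a nitrile or an amine here would track compound 2 or compound 3 remains open. So does whether the same exchange would have a similar effect on the core of compound 1.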